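Aza-substitution of the bicyclic arm in compound 1

A few compounds are considered here, and "the series" means these few. Any claim that something is new, unique, unknown or untested is made for them only; others in the source may bear on it.

Values in a functional assay on MCF7 cells (Homo sapiens) for cytotoxicity, read by CellTiter-Glo, with a stated time of 5 days; on this read-out higher numbers stand for weaker inhibition and lower numbers for stronger inhibition:
compound 1, `CC/C(=C(/c1ccc(/C=C/C(=O)O)cc1)c1ccc2[nH]ncc2c1)c1ccccc1`: 7.2 nM
compound 3, `CC(C)/C(=C(/c1ccc(/C=C/C(=O)O)cc1)c1ccc2[nH]ncc2c1)c1ccccc1`: 4 nM
compound 2, `O=C(O)/C=C/c1ccc(/C(=C(/CCO)c2ccccc2)c2ccc3[nH]ncc3c2)cc1`: > 1000 nM, a limit

Of the two numbers shown, compound 1 gives the higher; the nearest is compound 3, a 1.8-fold lower number from compound 1 to compound 3 (0.26 log units; within the scatter), within the scatter. For compound 2 only a limit is known: the limit of > 1000 nM in this assay, at which 1 of the 3 values shown sits. The step to compound 4, `CC/C(=C(/c1ccc(/C=C/C(=O)O)cc1)c1ccc2[nH]ncc2n1)c1ccccc1`, alters the bicyclic arm: a group of 9 heavy atoms (6 carbon, 3 nitrogen; one five-membered aromatic ring with 2 hetero atoms, one six-membered aromatic ring with 1 hetero atom) in place of a group of 9 heavy atoms (7 carbon, 2 nitrogen; one five-membered aromatic ring with 2 hetero atoms, one six-membered aromatic ring of carbon only), on a double-bonded chain carbon bound to an aromatic carbon and a double-bonded chain carbon. For the measured compounds named here, no measured step alters this group; the large steps of an at least 130-fold higher number from compound 1 to compound 2 (2.14 log units; beyond the scatter) and an at least 250-fold lower number from compound 2 to compound 3 (2.39 log units; beyond the scatter) concern the other double-bonded chain carbon, and the only step from compound 1, a 1.8-fold lower number from compound 1 to compound 3 (0.26 log units; within the scatter), is within the scatter. The step in this assay is therefore expected to be small, if anything a slightly higher number. Compound 4 is estimated at 12 nM, between 4 nM and 40 nM, an expected step of a 1.7-fold higher number from compound 1 to compound 4 (0.22 log units; within the scatter).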

Compound 4, half-maximal inhibitory concentration: 33 nM
The estimate for compound 4 lay 2.8-fold (0.44 log units) below the measured number; the measured number falls inside the stated range.
By their numbers in this assay, from the lowest: compounds 3 and 1 (each within the scatter of the next); then compound 4. At a limit, above all of these: compound 2.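

In this assay, for the compounds shown here, the bicyclic arm, which no earlier step altered, proves sensitive to a single ring change: replacing 1H-indazol-5-yl with the arm carrying one more ring nitrogen gives a 4.6-fold higher number from compound 1 to compound 4 (0.66 log units; beyond the scatter). The step is modest, so this place accepts the extra hydrogen-bond acceptor with a measurable but limited cost in this read-out. Nothing shown accounts for this step.

From the compounds shown here alone, it remains open whether the same exchange on compound 3 would give a similar step. Also open, going by these compounds, is how an amine or a methoxy group on the six-membered ring of this arm would read.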